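Substituent swap on the benzyl ether: compound 4

The compounds below may be only part of what the source reports. "The series", "measured", "known", "first", "only" and "open" are said of these compounds alone.

Compound 3 `COc1ccc(COc2ccc3c(Cn4ccnc4)cc(=O)oc3c2)cc1` gives 1% in an assay for inhibition of steroid 17-alpha-hydroxylase/17,20 lyase (Homo sapiens), read by HPLC, with a stated time of 5 min, tested at 2.5 uM, in the presence of a further agent that is not named here; a higher number here means more inhibition at the concentration tested (going by the name of the read-out), a lower number less inhibition. It stands second highest of the three numbers, next to compound 1 `O=c1cc(Cn2ccnc2)c2ccc(OCc3cccc(F)c3)cc2o1` with 0% and compound 2 `COc1cccc(COc2ccc3c(Cn4ccnc4)cc(=O)oc3c2)c1` with 2%; both gaps lie within the scatter, as a number 1 percentage points higher from compound 1 to compound 3 (within the scatter) and a number 1 percentage points lower from compound 2 to compound 3 (within the scatter) show. Compound 4 `Cc1cccc(COc2ccc3c(Cn4ccnc4)cc(=O)oc3c2)c1` differs from compound 3 by 3-methylphenyl in place of 4-methoxyphenyl on a saturated chain carbon bound to an oxygen on an aromatic ring. The measured steps that bear on this change, a number 2 percentage points higher from compound 1 to compound 2 (within the scatter), a number 1 percentage points higher from compound 1 to compound 3 (within the scatter) and a number 1 percentage points lower from compound 2 to compound 3 (within the scatter), all fall within the scatter. Each variation of this group among the measured compounds leaves inhibition near zero, so no step beyond the scatter is expected for compound 4: no change at the digits printed from compound 3 to compound 4 (within the scatter). Compound 4 is therefore estimated at 1%, with a range from 0% to 10%.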

Compound 4, a percentage reported as inhibition, at one concentration (the size of the read-out at that concentration, not a potency): 0%
Compound 4: middle estimate off by 1 percentage points, on the high side; the measured number falls inside the stated range.
By their numbers in this assay, from the lowest: compounds 1, 4, 3 and 2 (each within the scatter of the next).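

In this assay 3-methylphenyl in place of 4-methoxyphenyl gives a number 1 percentage points lower from compound 3 to compound 4 (within the scatter) and methyl in place of methoxy on an aromatic carbon gives a number 2 percentage points lower from compound 2 to compound 4 (within the scatter) while exchanging the fluoro group for a methyl group gives no change at the digits printed from compound 1 to compound 4 (within the scatter) as well. A plain methyl group therefore reads the same as methoxy and fluoro here, and 3-methylphenyl, with 0 hydrogen-bond acceptors against 1 for 4-methoxyphenyl, adds no measurable inhibition. Nothing available explains this flat reading.

As far as these compounds go, whether an amine, a carboxylic acid or a longer chain on this benzyl group would give measurable inhibition remains open. So does whether any change to the shared core would.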